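Removing the phenolic hydroxy from compound 2

The source may hold more compounds than are shown below. What is called first, only, known or untested is meant among the compounds shown, and "the series" means these compounds.

Three compounds of the shared core have numbers in a functional assay on PANC-1 cells (Homo sapiens) for inhibition, read by sulforhodamine B assay, with a stated time of 48 h; on this read-out lower numbers stand for stronger inhibition of growth and higher numbers for weaker inhibition of growth. Compound 1 `Cc1ccn2c(CN3CCCCC3)c(-c3ccccc3)nc2n1` gives 20 nM in this assay. Compound 2 `Oc1ccc(-c2nc3ncccn3c2CN2CCCCC2)cc1` gives 200 nM in this assay. Compound 3 `Cc1ccn2c(CN3CCCC3)c(-c3ccc(O)cc3)nc2n1` gives 7280 nM in this assay. Compound 2 therefore stands second highest of the three numbers: compound 1 is its nearest neighbour with a lower number beyond the scatter, and compound 3 is furthest with a higher number beyond the scatter. Within the data shown here, compound 1 and compound 2 differ in more than one place, so no single step between measured compounds is available to calibrate the change in hand.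

Compound 4 `c1ccc(-c2nc3ncccn3c2CN2CCCCC2)cc1` is not yet measured. It differs from compound 2 as follows: hydrogen in place of hydroxy on an aromatic carbon. Compound 1 carries the phenyl without hydroxy and gives 20 nM, which points toward a lower number for compound 4, though the methyl on the core of compound 1 is absent in compound 4 and compound 2 alike. The step is therefore expected as modest, toward a lower number, and not certain to exceed the scatter. For compound 4 the estimated value in this assay is 70 nM, with a range of 15 nM to 300 nM, which means an expected step of a 2.9-fold lower number from compound 2 to compound 4 (0.46 log units; beyond the scatter).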

Compound 4, concentration for 50% growth inhibition: 1310 nM
Beside the measured number, compound 4's estimate is 19-fold (1.27 log units) below it; the whole stated range lies below it.
By their numbers in this assay, from the lowest: compound 1; then compound 2; then compound 4; then compound 3.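

In this assay, going from 4-hydroxyphenyl to phenyl gives a 6.6-fold higher number from compound 2 to compound 4 (0.82 log units; beyond the scatter), so on the shared core without the methyl, the hydroxy goes with stronger inhibition of growth, not weaker. Hydrogen in place of methyl on an aromatic carbon of the core gives a 66-fold higher number from compound 1 to compound 4 (1.82 log units; beyond the scatter), a large step against the modest one at the hydroxy, so the low number of compound 1 goes with the methyl and cannot be credited to the bare phenyl. Nothing on hand explains either step.

On these data alone, whether the hydroxy step keeps its direction with the core methyl present stays open, since compound 3 differs from compound 1 in more than one place and that step cannot be read. Also open, as far as these compounds go, is how a methoxy or an amine would compare with the hydroxy at the same place on the ring.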